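Swapping Chloro for Nitro on a Cytotoxicity Read-out

A few compounds are considered here, and "the series" means these few. Any claim that something is new, unique, unknown or untested is made for them only; others in the source may bear on it.

Measured so far:
compound 1 `Nc1ccc(Oc2ccccc2-c2ccc(S(=O)(=O)NCCNC(=O)Nc3ccc(Cl)cc3)s2)cc1` — > 20000 nM
compound 2 `O=S(=O)(NCCNC(=S)Nc1ccc(Cl)cc1)c1ccc(-c2ccccc2OCc2ccccc2)s1` — 12100 nM
compound 3 `COc1ccc(Oc2ccc([N+](=O)[O-])cc2-c2ccsc2S(=O)(=O)N2CCN(C(=S)Nc3ccc([N+](=O)[O-])cc3)CC2)cc1OC` — > 50000 nM

Of the compounds shown here, three have been measured in an ADME assay on HEK-293T cells (Homo sapiens) for cytotoxicity, read by CCK-8 assay, with a stated time of 48 h; on this read-out higher numbers stand for weaker inhibition and lower numbers for stronger inhibition. Compound 1 gives > 20000 nM; this is a limit of the measurement, not a number, and compound 1 sits at the limit of > 20000 nM in this assay, at which 1 of the 3 values shown sits. Compound 3 gives > 50000 nM, likewise a limit, and compound 3 sits at the limit of > 50000 nM in this assay, at which 1 of the 3 values shown sits. Among the measured compounds shown here, compound 2 is the only one with a definite number: compound 2 gives 12100 nM. The other two reach only a limit; compound 2 cannot be ranked against them.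

Compound 4 `O=[N+]([O-])c1ccc(NC(=S)NCCNS(=O)(=O)c2ccc(-c3ccccc3OCc3ccccc3)s2)cc1` has not yet been measured. It differs from compound 2 in one place: nitro in place of chloro on an aromatic carbon. For the measured compounds named here, no two measured compounds differ in a single place, and no measured step shows what this change does here. The expected step, a 1.0-fold lower number from compound 2 to compound 4 (0.00 log units; within the scatter), is none beyond the scatter, in either direction. Compound 4 is accordingly estimated at 12000 nM, between 4000 nM and 40000 nM, with a fair chance that only a limit is reported.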

Compound 4, half-maximal inhibitory concentration: 8900 nM
Estimate against measurement, compound 4: 1.3-fold (0.13 log units) above, and the stated range covers the measured number.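

In this assay, going from 4-chlorophenyl to 4-nitrophenyl gives a 1.4-fold lower number from compound 2 to compound 4 (0.13 log units; within the scatter), even though nitro brings 3 heavy atoms and 2 hydrogen-bond acceptors where chloro had 1 heavy atom and no acceptors. Among the compounds shown here, none of the earlier compounds differed in a single place, so this is the first direct reading of a change at this position, and here the larger group leaves the number within the usual scatter. Nothing measured here gives a reason for this result.

A single step cannot show how other groups would behave at this position, such as a carboxylic acid or a dimethylamino group. It also leaves open whether the same swap would act alike on the core of compound 1, which also carries 4-chlorophenyl but reaches only a limit.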